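Aryl exchange in the series: compound 2 to compound 4

The compounds below may be only part of what the source reports. "The series", "measured", "known", "first", "only" and "open" are said of these compounds alone.

Measured so far in a functional assay on SW-620 cells (Homo sapiens) for cytotoxicity, read by sulforhodamine B assay, with a stated time of 48 h (on this read-out lower numbers stand for stronger inhibition and higher numbers for weaker inhibition), as follows:
- compound 1 `C[C@H]1CC[C@@H]2[C@@H](OC(=O)[C@]23CC(c2ccccc2Br)=NO3)[C@]2(C)C(=O)C=C[C@@]12O` gives 44000 nM
- compound 2 `C[C@H]1CC[C@@H]2[C@@H](OC(=O)[C@]23CC(c2ccccc2)=NO3)[C@]2(C)C(=O)C=C[C@@]12O` gives 45400 nM
- compound 3 `C[C@H]1CC[C@@H]2[C@@H](OC(=O)[C@]23CC(c2ccccc2[N+](=O)[O-])=NO3)[C@]2(C)C(=O)C=C[C@@]12O` gives 40000 nM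

Compound 2 stands level with the other two, and no gap among the three goes beyond the scatter. The next structure is compound 4 `COc1cc(C2=NO[C@]3(C2)C(=O)O[C@@H]2[C@H]3CC[C@H](C)[C@]3(O)C=CC(=O)[C@@]23C)ccc1O` and the change is 4-hydroxy-3-methoxyphenyl in place of phenyl on a carbon with a double bond to nitrogen on a carbon with a double bond to nitrogen. The measured steps on the aromatic ring are a 1.0-fold higher number from compound 1 to compound 2 (0.01 log units; within the scatter) and a 1.1-fold lower number from compound 2 to compound 3 (0.05 log units; within the scatter) and both lie within the scatter. Neither step tests a hydroxy or methoxy group, so the range stays wide. No step beyond the scatter is expected in this assay and the expected change is a 1.2-fold lower number from compound 2 to compound 4 (0.08 log units; within the scatter) on this basis. Compound 4 is estimated at 38000 nM with an expected range from 18000 nM to 75000 nM for now.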

Compound 4, half-maximal inhibitory concentration: 88000 nM
Compound 4: middle estimate off by 2.3-fold (0.36 log units), on the low side; the whole stated range lies below it.
By their numbers in this assay, from the lowest: compounds 3, 1, 2 and 4 (each within the scatter of the next, the first and the last beyond it).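

Among these compounds, at this position, the exchange to 4-hydroxy-3-methoxyphenyl gives the first step in this assay beyond the scatter, though a modest one (a 2.2-fold higher number from compound 3 to compound 4 (0.34 log units; beyond the scatter)). The steps from the other two aryl compounds stay within the scatter (a 1.9-fold higher number from compound 2 to compound 4 (0.29 log units; within the scatter); a 2.0-fold higher number from compound 1 to compound 4 (0.30 log units; within the scatter)), so this change separates compound 4 from compound 3 only. No evidence at hand bears on this step.

The compounds shown leave open whether the hydroxy or the methoxy group alone would give the same reading. On these data alone, how an amine or a carboxylic acid on the aromatic ring would read here also stays open.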